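From 1-methyl-1H-pyrazol-5-yl to pyridin-4-yl at the limit

A few compounds are considered here, and "the series" means these few. Any claim that something is new, unique, unknown or untested is made for them only; others in the source may bear on it.

For the measured compounds named here, in a functional assay on A-375 cells (Homo sapiens) for inhibition, read by sulforhodamine B assay, with a stated time of 6 days (on this read-out lower numbers stand for stronger inhibition and higher numbers for weaker inhibition), compound 1 (`CNCCNCc1cccc(-c2nc(NC3CCOCC3)c(C)c(-c3ccnc4[nH]ccc34)n2)c1`) gives 18200 nM as the only true number among the compounds measured so far. Compound 2 (`CNCCNCc1cccc(-c2nc(NC3CCOCC3)c(C)c(-c3cncnc3)n2)c1`) reaches only a limit of the assay, > 50000 nM and no number. Compound 3 (`CNCCNCc1cccc(-c2nc(NC3CCOCC3)c(C)c(-c3ccnn3C)n2)c1`) also stands at a limit, > 50000 nM and no number, so its place is known from one side only.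

Compound 4 (`CNCCNCc1cccc(-c2nc(NC3CCOCC3)c(C)c(-c3ccncc3)n2)c1`) differs from compound 3 in one place, with pyridin-4-yl in place of 1-methyl-1H-pyrazol-5-yl on an aromatic carbon. Going by the values given here, two measured steps bear on this change, an at least 2.7-fold higher number from compound 1 to compound 2 (0.43 log units; beyond the scatter) and an at least 2.7-fold higher number from compound 1 to compound 3 (0.43 log units; beyond the scatter) and both run in the same direction. The step that the two limits leave unreadable from compound 2 to compound 3 gives no size to work with. Pyridin-4-yl is a single aromatic ring, as the groups of compound 2 and compound 3 are, and not the two-ring group of compound 1. With the limit of > 50000 nM in this assay, at which 2 of the 3 values shown sit, as the remaining guide, compound 4 is expected to stay weak, near that limit. In this assay the estimated change is an at least 1.1-fold lower number from compound 3 to compound 4 (0.04 log units; that floor lies within the scatter) and no clear step beyond the scatter is expected. For compound 4 the estimated value is 45000 nM with an expected range from 18000 nM to 90000 nM and a report of only a limit is quite likely.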

Compound 4, half-maximal inhibitory concentration: 44300 nM
Estimate against measurement, compound 4: 1.0-fold (0.01 log units) above; the range from low to high includes it.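

For the compounds shown here, with pyridin-4-yl on this aromatic carbon, compound 4 is the first compound with a single-ring group here to give a true number in this assay, but the steps of an at least 1.1-fold lower number from compound 3 to compound 4 (0.05 log units; that floor lies within the scatter) and an at least 1.1-fold lower number from compound 2 to compound 4 (0.05 log units; that floor lies within the scatter) have floors within the scatter, so no gain over either earlier group can be claimed. The two-ring group of compound 1 now has a measured comparison with a single-ring group at this position, and the replacement gives a 2.4-fold higher number from compound 1 to compound 4 (0.39 log units; beyond the scatter). The comparisons with the other two single-ring groups remain one-sided, and the new value lies close to the limit that bounds them: the limit of > 50000 nM in this assay, at which 2 of the 4 values shown sit.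

On these data alone, it remains open whether an amine or a methoxy group on the pyridin-4-yl ring would move the number toward that of compound 1 or further from it. The compounds shown also leave open whether pyridin-3-yl, or another two-ring group such as indol-4-yl, would behave like the group of compound 1 or like the single-ring groups on this same carbon.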